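The source may report more compounds than this note shows. Statements on the series, on what has been measured and on what is new or still open speak of the compounds shown alone.

Compounds and their values in this study:

Compound 1, `C=C1C(=O)[C@]23C[C@@]1(O)CC[C@H]2c1ccc(O)c(C)c1[C@@H]3Cn1cc(-c2ccc(C)cc2)nn1`, 1260 nM
Compound 2, `C=C1C(=O)[C@]23C[C@@]1(O)CC[C@H]2c1ccc(OS(=O)(=O)c2ccc(C)cc2)c(C)c1[C@@H]3Cn1cc(-c2ccc(C)cc2)nn1`, 1830 nM
Compound 3, `COc1ccc(-c2cn(C[C@H]3c4c(ccc(OS(=O)(=O)c5ccc(C)cc5)c4C)[C@@H]4CC[C@@]5(C)C[C@]43CC5=O)nn2)cc1`, given as a limit

The study reports measurements in a functional assay on A549 cells (Homo sapiens) for cytotoxicity, read by MTT assay, with a stated time of 4 days; on this read-out higher numbers stand for weaker inhibition and lower numbers for stronger inhibition. Compound 1 gives 1260 nM in this assay, the lowest of the two numbers shown. Compound 2 gives 1830 nM, and the step from compound 1 to compound 2, (4-methylphenyl)sulfonyl in place of hydrogen on an oxygen on an aromatic ring, amounts to a 1.5-fold higher number from compound 1 to compound 2 (0.16 log units; within the scatter). For compound 3 this assay gives only a limit, > 20000 nM, and not a number (the limit of > 20000 nM in this assay, at which 1 of the 3 values shown sits).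

Compound 4, `C=C1C(=O)[C@]23C[C@@]1(O)CC[C@H]2c1ccc(O)c(C)c1[C@@H]3Cn1cc(-c2ccccn2)nn1`, has not yet been measured. It differs from compound 1 in one place: pyridin-2-yl in place of 4-methylphenyl on an aromatic carbon. Going by the values given here, none of the measured steps touches the group on the five-membered aromatic ring with 3 nitrogen, so no measured step bears directly on this change. Among the compounds with values here, the only step that was measured, from compound 1 to compound 2, lay within the scatter, and the limit of compound 3 sets no size for any single change. The account therefore expects no step beyond the scatter for compound 4, though with wider uncertainty than for a change that has been measured. The step from compound 1 to compound 4 is estimated as a 1.4-fold higher number from compound 1 to compound 4 (0.15 log units; within the scatter). Compound 4 is expected to give about 1800 nM, between 600 nM and 6000 nM, in this assay.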

Compound 4, half-maximal inhibitory concentration: 1570 nM
Estimate against measurement, compound 4: 1.1-fold (0.06 log units) above; measured number inside the range.
By their numbers in this assay, from the lowest: compounds 1, 4 and 2 (each within the scatter of the next). At a limit, above all of these: compound 3.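

Among the compounds with a number, only compound 4 changes the group on the aromatic carbon of the five-membered aromatic ring with 3 nitrogen, and in this assay this exchange gives a 1.2-fold higher number from compound 1 to compound 4 (0.10 log units; within the scatter). The position therefore accepts pyridin-2-yl, a ring with 1 hetero atom and 1 hydrogen-bond acceptor, in place of 4-methylphenyl, a ring of carbon only, with no step beyond the scatter, so that compound 1, compound 4 and compound 2 cannot be told apart in this read-out. Nothing measured here speaks to a cause for this result.

From the compounds shown here alone, with a single exchange at this position, it stays open whether an aminomethyl group, a carboxylic acid or a longer alkyl chain on that aromatic carbon would move the number beyond the scatter. Compound 3 stands at a limit, > 20000 nM, and differs from the other compounds in more than one place, so the steps to it cannot be read.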